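A Nitro Aryl Replaces a Dichloro Aryl on a Sulfonamide

The compounds below may be only part of what the source reports. "The series", "measured", "known", "first", "only" and "open" are said of these compounds alone.

Compound 1 `O=C(O)CC/C=C\C[C@H]1[C@H](F)CC[C@@H]1NS(=O)(=O)c1ccc(Cl)c(Cl)c1`: 1700 nM
Compound 2 `Cc1ccc(S(=O)(=O)N[C@H]2CC[C@@H](F)[C@@H]2CCCCOCC(=O)O)cc1`: 1800 nM
Compound 3 `O=C(O)CCC/C=C\C[C@H]1[C@H](F)CC[C@@H]1NS(=O)(=O)c1ccc2ccccc2c1`: 200 nM

All three were tested in a functional assay on a cell-free system (plasma) for inhibition of thromboxane A2 receptor (Homo sapiens), read by turbidimetry; on this read-out higher numbers stand for weaker inhibition and lower numbers for stronger inhibition. Compound 1 has the second highest of the three numbers; compound 2 lies within the scatter of it, while compound 3 stands beyond the scatter with a lower number. Compound 4 `O=C(O)CC/C=C\C[C@H]1[C@H](F)CC[C@@H]1NS(=O)(=O)c1ccccc1[N+](=O)[O-]` has not yet been measured in this assay. It differs from compound 1 by 2-nitrophenyl in place of 3,4-dichlorophenyl on a sulfonyl sulfur. Going by the values given here, no pair of measured compounds isolates this change, so nothing measured points to its size. A modest step toward a higher number, barely beyond the scatter, is expected: a 1.5-fold higher number from compound 1 to compound 4 (0.17 log units; within the scatter). Compound 4 is estimated at 2500 nM, with a range from 700 nM to 9000 nM.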

Compound 4, half-maximal inhibitory concentration: 560 nM
Estimate against measurement, compound 4: 4.5-fold (0.65 log units) above; the whole stated range lies above it.
By their numbers in this assay, from the lowest: compound 3; then compound 4; then compounds 1 and 2 (each within the scatter of the next).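

In this assay, changing the aryl group on a sulfonyl sulfur gives a 3.0-fold lower number from compound 1 to compound 4 (0.48 log units; beyond the scatter). This is a modest step but beyond the scatter, so the number responds to the aryl group at this position, and the two chlorines are not required for inhibition in this series. Nothing measured here accounts for the step.

The compounds shown leave open whether the nitro group or the loss of the two chlorines carries the step. They also leave open how a plain phenyl or an aminophenyl on the same sulfur would compare.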